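Two Acid Groups Added to an Amide Nitrogen

The source may report more compounds than this note shows. Statements on the series, on what has been measured and on what is new or still open speak of the compounds shown alone.

In a physicochemical assay for lipophilicity, using the shake flask method (on this read-out higher numbers stand for higher lipophilicity and lower numbers for lower lipophilicity), compound 1 `C[C@H](Oc1ccc2ncc(/C=C/C(N)=O)c(C3CC3)c2c1)c1c(Cl)ccc(F)c1Cl` reaches only a limit, > 5.5, which is the limit of > 5.5 in this assay, at which 1 of the 2 values shown sits. Compound 2 `C[C@H](Oc1ccc(NC(=O)CC(N)=O)c(C2CC2)c1)c1c(Cl)ccc(F)c1Cl`, a differently built relative, gives 3.9 in this assay. Compound 3 `C[C@H](Oc1ccc2ncc(/C=C/C(=O)NC(CC(=O)O)CC(=O)O)c(C3CC3)c2c1)c1c(Cl)ccc(F)c1Cl` has not been measured; it differs from compound 1 by 2-carboxy-1-(carboxymethyl)ethyl in place of hydrogen on an amide-type nitrogen. For the measured compounds named here, no measured pair here shows this kind of change, so the expectation rests on the change alone: a large fall, well beyond the scatter, is expected, a number at least 3.50 log units lower from compound 1 to compound 3 (beyond the scatter). Compound 3 is therefore estimated at 2, between 0.5 and 3.5.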

Compound 3, distribution coefficient: 0.4
Compound 3: the middle estimate sits 1.60 log units above what was measured, outside the stated range (below it).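

In this assay, 2-carboxy-1-(carboxymethyl)ethyl in place of hydrogen on the amide-type nitrogen gives a number at least 5.10 log units lower from compound 1 to compound 3 (beyond the scatter). This is the only step shown at this nitrogen, so the earlier compounds offered nothing to compare it with. Compound 1 stands only at a limit, so the full size of the fall remains unknown: the limit of > 5.5 in this assay, at which 1 of the 3 values shown sits.

The compounds shown leave open whether a chain carrying a single carboxylic acid, or an amine, on this nitrogen would give a fall of similar size. They also leave open how much each of the two carboxy arms contributes.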